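The source may hold more compounds than are shown below. What is called first, only, known or untested is meant among the compounds shown, and "the series" means these compounds.

- Compound 1 `O=C(/C(=C\c1ccc(Cl)cc1)S(=O)(=O)c1ccc(Br)cc1)c1ccc(Br)cc1` gives 50000 nM
- Compound 2 `CCOc1ccc(/C=C(/SCc2ccc(F)cc2)C(=O)c2ccc(Br)cc2)cc1OC` gives 50000 nM
- Compound 3 `COc1ccc(S(=O)(=O)/C(=C/c2ccc(C)s2)C(=O)c2ccc(Cl)cc2)cc1` gives 25000 nM

In a functional assay on DU-145 cells (Homo sapiens) for inhibition, read by trypan blue exclusion, with a stated time of 96 h (a lower number here means a stronger inhibitor of growth, a higher number a weaker inhibitor of growth), compound 1 stands level with compound 2, and compound 3 lies within the usual scatter of both. Compound 4 `O=C(/C(=C\c1ccc(Br)c(O)c1)S(=O)(=O)c1ccc(Br)cc1)c1ccc(Br)cc1` differs from compound 1 in one place (4-bromo-3-hydroxyphenyl in place of 4-chlorophenyl on a double-bonded chain carbon bound to a double-bonded chain carbon), with 4-bromo-3-hydroxyphenyl in place of 4-chlorophenyl on a double-bonded chain carbon bound to a double-bonded chain carbon. Among the measured compounds shown here, no two measured compounds differ in only one place, so the data offer no step to scale this change. A modest fall in the number is expected, though this expectation is weakly grounded and a result within the scatter remains possible. The expected change is a 4.2-fold lower number from compound 1 to compound 4 (0.62 log units; beyond the scatter) and remains an estimate. Compound 4 is estimated at 12000 nM (expected range 2000 nM to 50000 nM).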

Compound 4, concentration for 50% growth inhibition: 50000 nM
Estimate against measurement, compound 4: 4.2-fold (0.62 log units) below, within the range that was stated.
By their numbers in this assay, from the lowest: compounds 3, 1, 2 and 4 (each within the scatter of the next).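

In this assay, among the compounds shown here, 4-bromo-3-hydroxyphenyl in place of 4-chlorophenyl on a double-bonded chain carbon bound to a double-bonded chain carbon gives no change at the digits printed from compound 1 to compound 4 (within the scatter), the first step here that isolates one place. At this position, the entering hydroxyl and bromine together leave the number where it stood. Nothing measured here bears on why this is so.

The compounds shown leave open how the hydroxyl and the bromine would each read alone. They also leave open how an amine or a carboxylic acid would read on that ring.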